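Propanoyl for acetyl on a coumarin-type antagonist

The source may hold more compounds than are shown below. What is called first, only, known or untested is meant among the compounds shown, and "the series" means these compounds.

Three compounds have been measured in a functional assay on ileum (Cavia porcellus) for antagonist activity; a lower number here means a stronger inhibitor, a higher number a weaker inhibitor:
compound 1, `CCc1ccccc1OCC(O)COc1ccc2c(O)c([N+](=O)[O-])c(=O)oc2c1`, gives 2700 nM;
compound 2, `CC(C)c1ccccc1OCC(O)COc1ccc2c(O)c([N+](=O)[O-])c(=O)oc2c1`, gives 160 nM;
compound 3, `CCCc1c(OCC(O)COc2ccc3c(O)c([N+](=O)[O-])c(=O)oc3c2)ccc(C(C)=O)c1O`, gives 80 nM.

The difference between the core of compound 1 and the core of compound 3 is not broken down here. Compound 3 and compound 2 give numbers that lie within the usual scatter of each other, and both lie far from compound 1.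

Compound 4, `CCCc1c(OCC(O)COc2ccc3c(O)c([N+](=O)[O-])c(=O)oc3c2)ccc(C(=O)CC)c1O`, has not yet been measured. It differs from compound 3 by methyl in place of hydrogen on a saturated chain carbon bound to a carbonyl carbon. A change of the same kind has been measured once: from compound 1 to compound 2, which is methyl in place of hydrogen on a saturated chain carbon bound to an aromatic carbon and a saturated chain carbon, the number moved by a 17-fold lower number from compound 1 to compound 2 (1.23 log units; beyond the scatter). The two places are not identical, however: in the measured pair the saturated chain carbon is bound to an aromatic carbon and a saturated chain carbon, whereas in compound 4 it is bound to a carbonyl carbon.

Among the measured compounds shown here, for compound 4 a smaller step is expected than the one seen for compound 2, because a 17-fold lower number from compound 1 to compound 2 (1.23 log units; beyond the scatter) was recorded at a different place and on a different core, and because compound 3 already gives 80 nM. An expected step of a 1.6-fold lower number from compound 3 to compound 4 (0.20 log units; within the scatter) seems reasonable. Compound 4 is therefore estimated at 50 nM, with a range from 15 nM to 200 nM.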

Compound 4, half-maximal inhibitory concentration: 150 nM
The estimate for compound 4 lay 3.0-fold (0.48 log units) below the measured number, within the range that was stated.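

In this assay, propanoyl in place of acetyl gives a 1.9-fold higher number from compound 3 to compound 4 (0.27 log units; within the scatter), so methyl in place of hydrogen on a saturated chain carbon bound to a carbonyl carbon produces no change that can be told from the usual scatter of repeated measurements. The large gain seen on the earlier core therefore did not carry over to this one, and the gap between the two steps is real rather than noise: the same change on two cores in this assay, a 17-fold lower number (1.23 log units; beyond the scatter) from compound 1 to compound 2 and a 1.9-fold higher number (0.27 log units; within the scatter) from compound 3 to compound 4, 32-fold (1.50 log units) apart, beyond the scatter of two such steps. This does not show what separates the two results, since the added methyl stands at a different place in each pair and the cores differ as well, and with a single pair for each case the data cannot tell the effect of the place from that of the core.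

The compounds shown leave open how a longer chain than propanoyl, an amine or a carboxylic acid at this place would read in this assay. Also open, as far as these compounds go, is whether methyl in place of hydrogen on a saturated chain carbon bound to an aromatic carbon and a saturated chain carbon would give a large step on the core of compound 3, which would help separate place from core.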